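The source may hold more compounds than are shown below. What is called first, only, known or untested is meant among the compounds shown, and "the series" means these compounds.

Working notes on the series. Compound 1 `COc1cc(F)c(NC(=O)c2ccncc2)cc1Nc1nccc(-c2cn(C)c3ccccc23)n1` gives 4200 nM in a functional assay on A549 cells (Homo sapiens) for antiproliferative activity, read by MTT assay, with a stated time of 72 h; a lower number here means a stronger inhibitor, a higher number a weaker inhibitor. Compound 2 `COc1ccc(C(=O)Nc2cc(Nc3nccc(-c4cn(C)c5ccccc45)n3)c(OC)cc2F)nc1` gives 8200 nM in this assay. Compound 1 has the lower of the two numbers recorded so far, yet the step of a 2.0-fold higher number from compound 1 to compound 2 (0.29 log units; within the scatter) lies within the scatter, so no order between the two is claimed. Compound 3 `COc1cc(N(C)CCN(C)C)c(NC(=O)c2ccncc2)cc1Nc1nccc(-c2cn(C)c3ccccc23)n1` is not yet measured; it differs from compound 1 by (2-(dimethylamino)ethyl)(methyl)amino in place of fluoro on an aromatic carbon. Going by the values given here, the single measured step concerns the group on the carbonyl carbon and does not touch the aromatic carbon altered here, so it gives no direct guide to the size or direction of the new step. With no comparable change in the data, the expectation for compound 3 rests on compound 1 alone, and a modest move to a lower number, a 2.8-fold lower number from compound 1 to compound 3 (0.45 log units; beyond the scatter), is estimated, with a wide range. Compound 3 is therefore expected to give about 1500 nM in this assay, between 300 nM and 8000 nM.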

Compound 3, half-maximal inhibitory concentration: 10400 nM
For compound 3 the middle estimate is 6.9-fold (0.84 log units) below the measured one, outside the stated range (above it).
By their numbers in this assay, from the lowest: compounds 1, 2 and 3 (each within the scatter of the next, the first and the last beyond it).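

In this assay, going by these compounds alone, the step of a 2.5-fold higher number from compound 1 to compound 3 (0.39 log units; beyond the scatter) gives the first reading at the aromatic carbon ortho to the ((pyridin-4-yl)carbonyl)amino group, which the step on the carbonyl carbon did not touch. On this pair, (2-(dimethylamino)ethyl)(methyl)amino, with 7 heavy atoms in place of the single fluorine, brings no gain over fluoro, and the loss is modest for so large a replacement. Nothing at hand bears on why the number moves in this direction.

From the compounds shown here alone, whether a dimethylamino group, a carboxylic acid or a longer chain on this carbon would give a number lower than the fluoro compound remains open. Also open, going by these compounds, is whether the effect of this change would carry over when 5-methoxypyridin-2-yl stands on the carbonyl carbon.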